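From methanesulfonamido to ((4-methylphenyl)carbonyl)oxy on the saturated ring

The source may hold more compounds than are shown below. What is called first, only, known or untested is meant among the compounds shown, and "the series" means these compounds.

In an ADME assay on Vero cells (Chlorocebus sabaeus) for cytotoxicity, read by MTT assay, with a stated time of 48 h (a higher number here means a weaker inhibitor, a lower number a stronger inhibitor), compound 1 `CS(=O)(=O)OC1CCC(CN2CCN(c3cc(=O)c4cc(C(F)(F)F)cc([N+](=O)[O-])c4s3)CC2)CC1` gives > 64 ug/mL, a limit of the assay and not a number. Compound 2 `CC(C)S(=O)(=O)OC1CCC(CN2CCN(c3cc(=O)c4cc(C(F)(F)F)cc([N+](=O)[O-])c4s3)CC2)CC1` gives > 64 ug/mL, again only a limit. Among the compounds with values here, compound 3 `CS(=O)(=O)NC1CCC(CN2CCN(c3cc(=O)c4cc(C(F)(F)F)cc([N+](=O)[O-])c4s3)CC2)CC1` gives 48.5 ug/mL, the only true number of the three. Compound 4 `Cc1ccc(C(=O)OC2CCC(CN3CCN(c4cc(=O)c5cc(C(F)(F)F)cc([N+](=O)[O-])c5s4)CC3)CC2)cc1` carries ((4-methylphenyl)carbonyl)oxy in place of methanesulfonamido on a saturated ring carbon.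

Within the data shown here, two measured steps bear on this change: an at least 1.3-fold lower number from compound 1 to compound 3 (0.12 log units; that floor lies within the scatter) and an at least 1.3-fold lower number from compound 2 to compound 3 (0.12 log units; that floor lies within the scatter). Among the measured compounds shown here, each brought in methanesulfonamido in place of a group joined through oxy, and compound 4 returns to an oxy group, though one that no measured compound carries. The step that the two limits leave unreadable from compound 1 to compound 2 gives no size to work with. The two oxy compounds rest at the limit of > 64 ug/mL in this assay, at which 2 of the 3 values shown sit. The expected change is a 1.3-fold higher number from compound 3 to compound 4 (0.12 log units; within the scatter), towards a higher number and not clearly beyond the scatter. For compound 4 the estimate is 64 ug/mL, with an expected range from 35 ug/mL to 110 ug/mL.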

Compound 4, half-maximal inhibitory concentration: > 64 ug/mL
Compound 4 ended at the assay's limit (the forecaster's own chance of this, stated with the estimate: 60%); the middle value sits exactly at the limit.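

In this assay, the step at this saturated ring carbon reads an at least 1.3-fold higher number from compound 3 to compound 4 (0.12 log units; that floor lies within the scatter), so the size of the change remains unsettled. It does show that a group joined through oxy can carry a carbonyl and a six-membered aromatic ring of carbon only, rather than a sulfonyl group, and still give no true number. Compound 4 gives > 64 ug/mL, a limit of the assay and not a number. The steps linking compound 1 and compound 2 to compound 4 cannot be read, and all three oxy compounds now sit at the same edge of the assay: the limit of > 64 ug/mL in this assay, at which 3 of the 4 values shown sit.

From the compounds shown here alone, how far apart these three compounds truly lie remains open. So does whether an amine, or a (4-methylphenyl)carbonyl group joined through nitrogen, on the same ring carbon would give a true number in this assay.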